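This account rests on a few compounds, and the source may have more. Where it says the series, first, only, none or still open, it means among the compounds named here.

Compound 1, `CCC1(Cc2ccccc2)OS(=O)(=O)C=C1OCC1CCCCC1`, gives > 200000 nM in an ADME assay on HEL cells (Homo sapiens) for cytotoxicity, with a stated time of 3 days (a higher number here means that more compound is tolerated, a lower number that less compound is tolerated), a limit of the assay and not a number.
Compound 2, `CCC1(Cc2ccccc2)OS(=O)(=O)C=C1OCc1ccc(Cl)cc1`, gives > 200000 nM in this assay, likewise a limit of the assay.

Compound 2 therefore stands at the limit in this assay, where (the limit of > 200000 nM in this assay, at which 2 of the 2 values shown sit). Compound 3, `CCC1(Cc2ccccc2)OS(=O)(=O)C=C1OCc1ccc([N+](=O)[O-])cc1`, is not yet measured in this assay. It differs from compound 2 by nitro in place of chloro on an aromatic carbon. Going by the values given here, the only measured step that bears on this change is a step that the two limits leave unreadable from compound 1 to compound 2, and since both ends are limits, its size cannot be read. No step beyond the scatter is therefore expected in this assay from compound 2 to compound 3, and the result is expected to be a limit again. Compound 3 is estimated at 200000 nM, within a range from 100000 nM to 400000 nM. The step this estimate means is a number no higher from compound 2 to compound 3 (the limit leaves the size open), expected to lie within the scatter.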

Compound 3, half-maximal cytotoxic concentration: < 200000 nM
Compound 3: a limit, no number (the forecaster's own chance of this, stated with the estimate: 85%); the middle value sits exactly at the limit.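

With nitro in place of chloro on the aromatic carbon para to a large group, this assay shows a number no higher from compound 2 to compound 3 (the limit leaves the size open), and among the three compounds only compound 3 stands at a limit of the opposite sign: the limit of < 200000 nM in this assay, at which 1 of the 3 values shown sits. Compound 1 and compound 2, with cyclohexyl and 4-chlorophenyl, share the other limit: the limit of > 200000 nM in this assay, at which 2 of the 3 values shown sit. With 4-nitrophenyl in place of cyclohexyl, this assay shows a number no higher from compound 1 to compound 3 (the limit leaves the size open). The change at this position can therefore shift the read-out in a way the earlier pair could not show, with the number no higher than before, though the steps to compound 3 from compound 1 and compound 2 cannot be read in size.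

As far as these compounds go, how far compound 3 lies from the limit, and so whether its difference from compound 2 exceeds the usual scatter, remains open. So does what an amine or a carboxylic acid at the same position would give.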